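A few compounds are considered here, and "the series" means these few. Any claim that something is new, unique, unknown or untested is made for them only; others in the source may bear on it.

Measured compounds:
compound 1, `C=CS(=O)(=O)NC/C=C/c1cc(OC)cc(O)c1C(=O)OCc1ccc(Br)cc1`: 6240 nM
compound 2, `CCN(CC)C/C=C/C(=O)NC/C=C/c1cc(OCCc2ccc(F)cc2)cc(O)c1C(=O)OC(C)C`: > 10000 nM
compound 3, `COc1cc(O)c(C(=O)OCC(C)c2ccccc2)c(/C=C/CN2C(=O)C=CC2=O)c1`: > 10000 nM

Of the compounds shown here, three sharing one core have been tested in a functional assay on THP-1 cells (Homo sapiens) for antiproliferative activity, read by luminescence, with a stated time of 72 h; a higher number here means a weaker inhibitor, a lower number a stronger inhibitor. For the measured compounds named here, compound 1 gives 6240 nM in this assay, and this is the only value in the set that is an actual number. For compound 2 the result is a limit of the assay, > 10000 nM, not a number. For compound 3 the result is likewise a limit, > 10000 nM. Going by the values given here, compound 1 therefore stands as the sole compound with a measurable inhibitory concentration, while the other two sit at the limit of > 10000 nM in this assay, at which 2 of the 3 values shown sit. The two limits allow no sizing of any difference. Among the compounds with values here, no step between measured compounds can be given here, and nothing beyond the three values themselves is known.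

The compound not yet measured is compound 4, `C=CS(=O)(=O)NC/C=C/c1cc(OC)cc(O)c1C(=O)OC(C)C`. It is reached from compound 1 by a single change at the ester oxygen:

isopropyl in place of 4-bromobenzyl on an oxygen next to a carbonyl group

Within the data shown here, with no measured step to lean on, the expectation is drawn from the value of compound 1 alone. The ester substituent in compound 1 is the one clear point of difference, and its replacement by a much smaller group is expected to cost activity rather than gain it, with a step from compound 1 to compound 4 of about a 1.9-fold higher number from compound 1 to compound 4 (0.28 log units; within the scatter) in this assay, so somewhat beyond the scatter. Compound 4 is therefore estimated at 12000 nM, within a range from 4000 nM to 40000 nM, with a real chance that only a limit is reported.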

Compound 4, half-maximal inhibitory concentration: 14700 nM
Beside the measured number, compound 4's estimate is 1.2-fold (0.09 log units) below it, and the stated range covers the measured number.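

For the compounds shown here, compound 1 and compound 4 form the first pair in the set that differs in one place, so the ester substituent can now be sized: in this assay, isopropyl in place of 4-bromobenzyl gives a 2.4-fold higher number from compound 1 to compound 4 (0.37 log units; beyond the scatter). The change is limited, even though it removes the six-membered aromatic ring and the bromine and leaves 3 heavy atoms where there were 8, and compound 4 still returns an actual number rather than a limit of the assay. Nothing shown measures a property that could account for this step.

Going by these compounds alone, the single step cannot say whether the difference follows from the ring, the bromine or the size of the group; a plain benzyl group would separate the bromine from the ring, and a longer chain such as n-butyl would separate chain length from the ring. As far as these compounds go, it also remains open whether the same step would appear with a different group in place of the sulfonamide side chain, such as a simple amine, since this ester change is seen on one background only.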